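Replacing a Ring Hydrogen with Cyclohexyloxy: Expected Potency

A few compounds are considered here, and "the series" means these few. Any claim that something is new, unique, unknown or untested is made for them only; others in the source may bear on it.

Compound 3 `NC(=O)c1ccc(-c2cccnc2)cc1` carries only a hydrogen at the carbon under consideration. In an assay on cells for inhibition of MAP kinase-interacting serine/threonine-protein kinase 1 (Homo sapiens), read by mobility shift assay, with stated times of 10 min and 60 min, in the presence of a further agent that is not named here (on this read-out lower numbers stand for stronger inhibition and higher numbers for weaker inhibition), compound 3 gives 8800 nM, the highest number among the three measured compounds; its nearest neighbour, compound 2 `NC(=O)c1ccc(-c2cccnc2)cc1OC1CCC1`, gives 1900 nM, and compound 1 `NCCOc1cc(-c2cccnc2)ccc1C(N)=O` gives 820 nM. Compound 4 `NC(=O)c1ccc(-c2cccnc2)cc1OC1CCCCC1` has not yet been measured; its change from compound 3 is cyclohexyloxy in place of hydrogen on an aromatic carbon. The measured step that bears most directly on this is a 4.6-fold higher number from compound 2 to compound 3 (0.67 log units; beyond the scatter), where the cyclobutyloxy group occupies the same carbon, and more distantly an 11-fold higher number from compound 1 to compound 3 (1.03 log units; beyond the scatter). Both show that a group on this carbon in place of hydrogen lowers the number beyond the scatter, with cyclobutyloxy giving a modest step and 2-aminoethoxy a large one. Cyclohexyloxy is closest in kind to the cyclobutyloxy of compound 2, so for compound 4 a modest drop of about that size is expected. The expected step is a 4.4-fold lower number from compound 3 to compound 4 (0.64 log units; beyond the scatter). Compound 4 is therefore estimated at 2000 nM, with a range from 700 nM to 6000 nM.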

Compound 4, half-maximal inhibitory concentration: 1500 nM
For compound 4 the middle estimate is 1.3-fold (0.12 log units) above the measured one; low and high end bracket the measured number.
By their numbers in this assay, from the lowest: compounds 1, 4 and 2 (each within the scatter of the next, the first and the last beyond it); then compound 3.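

In this assay, cyclohexyloxy on this carbon also improves on hydrogen (a 5.9-fold lower number from compound 3 to compound 4 (0.77 log units; beyond the scatter)), so the gain seen with cyclobutyloxy and 2-aminoethoxy now holds for a third group on the same oxygen-linked carbon. Enlarging the ring on that oxygen from cyclobutyl to cyclohexyl gives no readable change (a 1.3-fold lower number from compound 2 to compound 4 (0.10 log units; within the scatter)), so these two ring sizes cannot be told apart here. Cyclohexyl and 2-aminoethyl on the oxygen also stay within the scatter (a 1.8-fold higher number from compound 1 to compound 4 (0.26 log units; within the scatter)), even though cyclobutyl and 2-aminoethyl do not, so the amine of compound 1 cannot be credited with a clear advantage over every ring.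

The compounds shown leave open how a small methoxy group, or a longer chain ending in an amine, would read on this carbon. Nothing available explains these steps.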